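Cytotoxicity limits and one end-group swap

The source may hold more compounds than are shown below. What is called first, only, known or untested is meant among the compounds shown, and "the series" means these compounds.

- compound 1 `C/C(=C/CC[C@@H](C)CC(=O)O)CC/C=C(/C)CCCc1ccoc1`: > 100 ug/mL (a limit)
- compound 2 `CC1=C(O)/C(=C/[C@H](C)CC/C=C(/C)CC/C=C(/C)CCCC2=CC(O)OC2=O)OC1=O`: > 100 ug/mL (a limit)
- compound 3 `COC(=O)C(C)(O)[C@](O)(C[C@H](C)CCC/C(C)=C/CC/C(C)=C/CCc1ccoc1)C(=O)OC`: 20 ug/mL

In a functional assay on K562 cells (Homo sapiens) for cytotoxicity, read by MTT assay (on this read-out lower numbers stand for higher toxicity in this test and higher numbers for lower toxicity in this test), compound 2 gives only a limit, > 100 ug/mL. Compound 1 shares it, as the limit of > 100 ug/mL in this assay, at which 2 of the 3 values shown sit, shows. Only compound 3 gives a true number, 20 ug/mL.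

Compound 4 `COC1C=C(CCC/C(C)=C\CC/C(C)=C\CC[C@@H](C)/C=C2\OC(=O)C(C)=C2O)C(OC)O1` differs from compound 2 at one end of the chain: a group of 9 heavy atoms (6 carbon, 3 oxygen; one five-membered non-aromatic ring with 1 hetero atom) in place of a group of 7 heavy atoms (4 carbon, 3 oxygen; one five-membered non-aromatic ring with 1 hetero atom), on a saturated chain carbon, three bonds along the chain from a double-bonded chain carbon. Among the measured compounds shown here, no measured pair of compounds isolates this kind of change, so any forecast is rough. Compound 3 at 20 ug/mL shows that a number can be reached in this small set, so a modest move towards higher toxicity seems plausible. The expected at least 1.6-fold lower number from compound 2 to compound 4 (0.22 log units; that floor lies within the scatter) is small and may not clear the limit. For compound 4 the estimated value is 60 ug/mL, with an expected range of 20 ug/mL to 150 ug/mL.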

Compound 4, concentration lethal to 50% of the cells: 83 ug/mL
Estimate against measurement, compound 4: 1.4-fold (0.14 log units) below; low and high end bracket the measured number.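

In this assay, compound 4 gives a true number, 83 ug/mL, for a change at this end of the chain. Compound 2 gives only a limit. Putting the group of 9 heavy atoms in place of the group of 7 heavy atoms gives an at least 1.2-fold lower number from compound 2 to compound 4 (0.08 log units; that floor lies within the scatter), so this swap cannot yet be said to change toxicity in this test. The step is only a floor, and its starting point is a limit: the limit of > 100 ug/mL in this assay, at which 2 of the 4 values shown sit.

Going by these compounds, the true size of the step stays open. So does the result of an amine at this chain end.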